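Series notes: from compound 3 to compound 4

The compounds below may be only part of what the source reports. "The series", "measured", "known", "first", "only" and "open" are said of these compounds alone.

In a functional assay on MDA-MB-231 cells (Homo sapiens) for antiproliferative activity, read by MTT assay, with a stated time of 24 h (on this read-out higher numbers stand for weaker inhibition and lower numbers for stronger inhibition), compound 3 `O=C(Nc1ccc(C(F)(F)F)cc1)N1CCN(c2nccc(Oc3cc(Cl)cc(Cl)c3)n2)CC1` gives 1540 nM, the lowest of the two actual numbers in the series. Compound 2 `O=C(Nc1ccc2ccccc2c1)N1CCN(c2nccc(Oc3cc(Cl)cc(Cl)c3)n2)CC1` gives 46800 nM. Compound 1 `O=S(=O)(c1ccc(F)cc1)N1CCN(c2nccc(Oc3cc(Cl)cc(Cl)c3)n2)CC1` reads > 50000 nM, which is a limit of the assay and not a number.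

Compound 4 `CN1CCN(CC(=O)N2CCN(c3nccc(Oc4cc(Cl)cc(Cl)c4)n3)CC2)CC1` carries (4-methylpiperazin-1-yl)methyl in place of (4-(trifluoromethyl)phenyl)amino on a carbonyl carbon. Among the measured compounds shown here, the one measured step bearing on this change is a 30-fold lower number from compound 2 to compound 3 (1.48 log units; beyond the scatter), which is large and shows that the group on the amide-type nitrogen can shift the number strongly. That step only swaps one aromatic group for another, whereas compound 4 loses the aromatic ring and the amino group altogether, so a step towards a higher number is expected. Also relevant is the limit of > 50000 nM in this assay, at which 1 of the 3 values shown sits, which the upper end of the expected range approaches.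

The expected change is a 9.7-fold higher number from compound 3 to compound 4 (0.99 log units; beyond the scatter). For compound 4 the estimated value is 15000 nM, with an expected range of 4000 nM to 50000 nM.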

Compound 4, half-maximal inhibitory concentration: 24700 nM
Compound 4: the middle estimate sits 1.6-fold (0.22 log units) below what was measured; the measured number falls inside the stated range.
By their numbers in this assay, from the lowest: compound 3; then compounds 4 and 2 (each within the scatter of the next). At a limit, above all of these: compound 1.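

In this assay, the change on the carbonyl carbon gives a 16-fold higher number from compound 3 to compound 4 (1.21 log units; beyond the scatter), so (4-methylpiperazin-1-yl)methyl does not keep the low number of compound 3. The same group in place of (naphthalen-2-yl)amino gives a 1.9-fold lower number from compound 2 to compound 4 (0.28 log units; within the scatter), so the two cannot be told apart here, although of the two groups only (naphthalen-2-yl)amino has an aromatic ring and the amide hydrogen. Those two features are therefore not enough on their own at this position, and the low number goes with (4-(trifluoromethyl)phenyl)amino in particular. ((4-Methylpiperazin-1-yl)methyl)carbonyl in place of (4-fluorophenyl)sulfonyl on an amine nitrogen in a ring gives an at least 2.0-fold lower number from compound 1 to compound 4 (0.30 log units; that floor lies within the scatter), which shows no clear difference. The value of compound 1 is a limit and not a number: the limit of > 50000 nM in this assay, at which 1 of the 4 values shown sits.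

Going by these compounds, it stays open whether the trifluoromethyl group itself matters or the phenylamino unit carrying it. Phenylamino groups bearing chlorine or a nitrile instead of trifluoromethyl would separate these two readings.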